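This account rests on a few compounds, and the source may have more. Where it says the series, first, only, none or still open, it means among the compounds named here.

Within the data shown here, compound 2 `CCCc1cc2ccccc2nc1-c1cc(-c2ccccc2)no1` is the only member of the series with a number in a functional assay on PC-3 cells (Homo sapiens) for inhibition, read by MTT assay, with a stated time of 24 h; on this read-out lower numbers stand for stronger inhibition and higher numbers for weaker inhibition; compound 2 gives 51300 nM. Compound 1 `CCc1cc2ccccc2nc1-c1cc(-c2ccccc2)no1` gives only a limit of the assay, > 100000 nM. Compound 3 `CCCCCc1cc2ccccc2nc1-c1cc(-c2ccccc2)no1` also sits at a limit, > 100000 nM. The steps of an at least 1.9-fold lower number from compound 1 to compound 2 (0.28 log units; that floor lies within the scatter) and an at least 1.9-fold higher number from compound 2 to compound 3 (0.28 log units; that floor lies within the scatter) are both floored by the limit of > 100000 nM in this assay, at which 2 of the 3 values shown sit, so neither shows a readable size. Compound 4 `CCCc1cc2ccccc2nc1-c1cc(-c2ccc(C)cc2)no1` differs from compound 2 by methyl in place of hydrogen on an aromatic carbon. All measured steps change the chain on the shared core; none touches the phenyl, so none bears directly on this change. No step beyond the scatter is expected in this assay. Compound 4 is expected near 50000 nM, within 15000 nM to 150000 nM, which means an expected step of a 1.0-fold lower number from compound 2 to compound 4 (0.01 log units; within the scatter).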

Compound 4, half-maximal inhibitory concentration: > 100000 nM
Compound 4: no number, only a limit; the forecaster's own chance of this, stated with the estimate: 35%; middle value at least 2.0-fold (0.30 log units) away from the limit.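

This is the only change shown on the phenyl rather than the chain, and phenyl to 4-methylphenyl gives an at least 1.9-fold higher number from compound 2 to compound 4 (0.28 log units; that floor lies within the scatter) in this assay. Compound 4 gives only a limit of the assay, so this change has no readable size and is not shown to exceed the scatter. Compound 2 remains the only compound with a number, and the other compounds all sit at a limit: the limit of > 100000 nM in this assay, at which 3 of the 4 values shown sit.

From the compounds shown here alone, whether an amine or a carboxylic acid in place of the methyl on this aromatic carbon would give a number remains open. Going by these compounds, the true size of this step also remains open.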